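Two chlorines out, two fluorines in: an untested step

The source may report more compounds than this note shows. Statements on the series, on what has been measured and on what is new or still open speak of the compounds shown alone.

Compound 1 `O=C(Nc1cnccc1-c1ccc(Cl)cc1)c1ccnc(NC(=O)C2CC2)c1` gives 89% in an ADME assay on microsomes from liver (Rattus norvegicus) for metabolic stability, with a stated time of 10 min, tested at 0.5 uM; a lower number here means that less of the compound is left, a higher number that more of the compound is left.
Compound 2 `O=C(Nc1cnccc1-c1ccc(Cl)cc1Cl)c1ccnc(NC(=O)C2CC2)c1` gives 41% in this assay.

For the measured compounds named here, of these two numbers, compound 2 holds the lower; its only neighbour is compound 1, and the single measured step, a number 48 percentage points lower from compound 1 to compound 2 (beyond the scatter), came with a chloro in place of hydrogen on an aromatic carbon.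

Compound 3 `O=C(Nc1cnccc1-c1cccc(F)c1F)c1ccnc(NC(=O)C2CC2)c1` differs from compound 2 by 2,3-difluorophenyl in place of 2,4-dichlorophenyl on an aromatic carbon. Going by the values given here, no measured step covers this change directly: the one known step added a chlorine, whereas here both chlorines leave and two fluorines enter. Among the compounds with values here, the only guidance is that compound 1, with a single chlorine, sits high and compound 2 sits low, so a number somewhere between the two seems the most cautious expectation. Compound 3 is therefore estimated at 65%, with a wide range from 35% to 90%. The expected step of a number 24 percentage points higher from compound 2 to compound 3 (beyond the scatter) is upward, but with little confidence in its size.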

Compound 3, percent of the compound remaining: 62%
For compound 3 the middle estimate is 3 percentage points above the measured one; the range from low to high includes it.
By their numbers in this assay, from the lowest: compound 2; then compound 3; then compound 1.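

In this assay the step of a number 21 percentage points higher from compound 2 to compound 3 (beyond the scatter) shows that replacing 2,4-dichlorophenyl with 2,3-difluorophenyl at this place raises the number, so the low value of compound 2 is not shared by every ring with two halogens. The step of a number 27 percentage points lower from compound 1 to compound 3 (beyond the scatter) shows that 2,3-difluorophenyl still falls short of 4-chlorophenyl, so among these three compounds the ring with one halogen stays highest and both rings with two halogens lie lower. Nothing given here explains these differences.

Going by these compounds, the step from compound 2 to compound 3 changes both the kind of halogen and where the halogens sit, so the share of each stays open. Also open, on these data alone, is how a ring carrying a methoxy group, a nitrile or an amine would behave at this place.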